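The source may hold more compounds than are shown below. What is called first, only, known or untested is meant among the compounds shown, and "the series" means these compounds.

In a functional assay on PC-3 cells (Homo sapiens) for antiproliferative activity, read by MTT assay, with a stated time of 48 h (a lower number here means a stronger inhibitor, a higher number a weaker inhibitor), compound 3 `COc1ccc(N/C=C\C(=O)c2cn(-c3ccccc3)nc2-c2ccc(Cl)cc2)cc1` gives 10700 nM, the higher of the two numeric values in the series, while compound 1 `O=C(/C=C\Nc1ccc(Cl)cc1)c1cn(-c2ccccc2)nc1-c1ccc(Cl)cc1` gives 3890 nM. Compound 2 `O=C(/C=C\Nc1ccc(C(F)(F)F)cc1)c1cn(-c2ccccc2)nc1-c1ccc(Cl)cc1` reports only a limit, > 50000 nM.

The next change leads to compound 4 `COc1ccc(N/C=C\C(=O)c2cn(-c3ccccc3)nc2-c2cc(OC)c(OC)c(OC)c2)cc1`: 3,4,5-trimethoxyphenyl in place of 4-chlorophenyl on an aromatic carbon. For the measured compounds named here, no measured step touches this place, as the 4-chlorophenyl group is common to compounds 1, 2 and 3. The measured steps all change the group on the other aromatic ring. Trifluoromethyl in place of chloro gives an at least 12-fold higher number from compound 1 to compound 2 (1.10 log units; beyond the scatter), methoxy in place of chloro gives a 2.8-fold higher number from compound 1 to compound 3 (0.44 log units; beyond the scatter), and methoxy in place of trifluoromethyl gives an at least 4.6-fold lower number from compound 2 to compound 3 (0.66 log units; beyond the scatter). Going by the values given here, these steps show only that single changes can move the numbers in this assay; they do not set a direction for the new change.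

The central expectation is therefore no step beyond the scatter, with a slight lean towards a lower number and wide margins either way. The expected step is a 1.8-fold lower number from compound 3 to compound 4 (0.25 log units; within the scatter). For compound 4, the estimated value is 6000 nM, with an expected range of 1200 nM to 35000 nM.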

Compound 4, half-maximal inhibitory concentration: 9600 nM
Estimate against measurement, compound 4: 1.6-fold (0.20 log units) below; the range from low to high includes it.
By their numbers in this assay, from the lowest: compound 1; then compounds 4 and 3 (each within the scatter of the next). At a limit, above all of these: compound 2.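

In this assay, the exchange of 4-chlorophenyl for 3,4,5-trimethoxyphenyl, on an aromatic carbon of the five-membered aromatic ring with 2 nitrogen, gives a 1.1-fold lower number from compound 3 to compound 4 (0.05 log units; within the scatter). For the compounds shown here, this is the first measured change at this position, and with the methoxy group on the other aromatic ring held constant, it leaves the number within the scatter, whereas the exchange of chloro for methoxy on that other ring gives a 2.8-fold higher number from compound 1 to compound 3 (0.44 log units; beyond the scatter). Nothing measured here accounts for the result at this position.

The compounds shown leave open whether the same exchange stays within the scatter when chloro or trifluoromethyl replaces that methoxy group. They also leave open how an amine or a carboxylic acid on the phenyl ring at this position would read in this assay.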